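A few compounds are considered here, and "the series" means these few. Any claim that something is new, unique, unknown or untested is made for them only; others in the source may bear on it.

Compound 1 `Cc1ccc(-c2nc3ccccn3c2Sc2ccccc2)cc1` carries a 4-methylphenyl group on an aromatic carbon of its core, and a phenylsulfanyl group sits on the ring atom next to it. In an ADME assay on HEK293 cells (Homo sapiens) for inhibition, read by MTT assay, with a stated time of 48 h (on this read-out higher numbers stand for weaker inhibition and lower numbers for stronger inhibition), compound 1 gives > 100000 nM, which is a limit of the assay and not a number. This places compound 1 at the limit of > 100000 nM in this assay, at which 1 of the 2 values shown sits. For the measured compounds named here, compound 2 `CS(=O)(=O)c1ccc(-c2nc3ccccn3c2Sc2cccc3ccccc23)cc1`, the only other compound measured so far, gives 83200 nM in this assay. It differs from compound 1 in more than one place, so the two values do not show what any single change does.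

Compound 3 `c1ccc(Sc2c(-c3cccs3)nc3ccccn23)cc1` keeps the core of compound 1 and has thiophen-2-yl in place of 4-methylphenyl on an aromatic carbon. Going by the values given here, no measured pair tests this swap, so the expectation is cautious: no shift beyond the usual scatter in this assay, and no firm direction. The expected change is a number no higher from compound 1 to compound 3 (the limit leaves the size open). This expectation rests on compound 1, whose reading is > 100000 nM. For compound 3 the estimated value is 100000 nM, with an expected range from 40000 nM to 250000 nM.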

Compound 3, half-maximal inhibitory concentration: > 100000 nM
Compound 3 gave a limit, no number; the forecaster's own chance of this, stated with the estimate: 60%; the middle value sits exactly at the limit.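

In this assay compound 1 and compound 3 each give only a limit of the assay and not a number, so no step can be read between these two compounds. The compounds shown leave open whether thiophen-2-yl in place of 4-methylphenyl on an aromatic carbon changes the read-out at all, and in which direction.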